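A larger group on the ether chain of compound 1

The source may report more compounds than this note shows. Statements on the series, on what has been measured and on what is new or still open speak of the compounds shown alone.

Compound 1 `CCOCCOC1CCN(c2nc(N)c3cc(OC)c(OC)cc3n2)CC1` has the higher of the two numbers shown in an assay on brain for displacement of a labelled ligand from Adrenergic receptor alpha-1 (Rattus norvegicus) (a higher number here means a weaker inhibitor, a lower number a stronger inhibitor), where compound 1 gives 1.81 nM. Compound 2 `CCOC(C)COC1CCN(c2nc(N)c3cc(OC)c(OC)cc3n2)CC1` gives 0.99 nM. Among the compounds with values here, the one measured step, a 1.8-fold lower number from compound 1 to compound 2 (0.26 log units; within the scatter), lies within the scatter. Compound 3 `COc1cc2nc(N3CCC(OCC(C)(O)c4ccccc4)CC3)nc(N)c2cc1OC` differs from compound 1 by 1-hydroxy-1-phenylethyl in place of ethoxymethyl on a saturated chain carbon bound to an oxygen on a saturated carbon. That measured step touches the same chain but is far smaller than this change, so it gives only weak guidance; no shift beyond the scatter is expected. Compound 3 is estimated at 2 nM, between 0.5 nM and 8 nM, which would be an expected 1.1-fold higher number from compound 1 to compound 3 (0.04 log units; within the scatter).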

Compound 3, inhibition constant: 0.62 nM
Beside the measured number, compound 3's estimate is 3.2-fold (0.51 log units) above it; measured number inside the range.
By their numbers in this assay, from the lowest: compounds 3, 2 and 1 (each within the scatter of the next, the first and the last beyond it).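

In this assay, the 2-ethoxyethyl chain can give way to the much larger 2-hydroxy-2-phenylpropyl, with its aromatic ring and hydrogen-bond donor, without any loss of binding: the change brings a 2.9-fold lower number from compound 1 to compound 3 (0.47 log units; beyond the scatter) and is a modest gain. Set against the methyl-bearing chain, the same kind of change gives a 1.6-fold lower number from compound 2 to compound 3 (0.20 log units; within the scatter) and so separates those two compounds no further. No evidence is available on why the larger group is tolerated. Going by these compounds, the hydroxyl and the phenyl ring enter together, so their separate contributions remain open. A 2-phenylpropyl chain without the hydroxyl, or an amine in place of that hydroxyl, would separate them.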